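Trimming the Sulfonamide Tail of Compound 1

The source may hold more compounds than are shown below. What is called first, only, known or untested is meant among the compounds shown, and "the series" means these compounds.

The two measured compounds share one core. Compound 1 `CCC1C(=O)N(C)c2cnc(Nc3ccc(S(=O)(=O)NCCCO)cc3)nc2N1c1ccn(C)n1` carries a (3-hydroxypropyl)sulfamoyl group on its aniline, and compound 2 `CCC1C(=O)N(C)c2cnc(-n3ccc4cc(C(=O)NCC(C)C)ccc43)nc2N1c1ccn(C)n1` has an amide-bearing bicyclic substituent in place of that aniline. In an assay for inhibition of serine/threonine-protein kinase PLK2 (Homo sapiens), read by FRET and Z'-LYTE, with a stated time of 1 h (on this read-out lower numbers stand for stronger inhibition and higher numbers for weaker inhibition), compound 1 gives 192 nM, the higher of the two numbers recorded, while compound 2 gives 159 nM; the two values lie within the scatter of each other, so neither can be called the more potent.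

Compound 3 `CCC1C(=O)N(C)c2cnc(Nc3ccc(S(N)(=O)=O)cc3)nc2N1c1ccn(C)n1` has not yet been measured. It differs from compound 1 by hydrogen in place of 3-hydroxypropyl on a sulfonamide nitrogen, so that (3-hydroxypropyl)sulfamoyl becomes sulfamoyl. Going by the values given here, no pair of measured compounds shows a step of this kind, and its size can only be guessed. Since the two measured compounds differ widely in structure yet give values within the scatter, a modest step without a clear direction is expected, and a 1.3-fold higher number from compound 1 to compound 3 (0.11 log units; within the scatter) is the estimate. Compound 3 is therefore expected to give about 250 nM in this assay, with a range from 100 nM to 600 nM.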

Compound 3, half-maximal inhibitory concentration: 121 nM
The estimate for compound 3 lay 2.1-fold (0.32 log units) above the measured number; measured number inside the range.
By their numbers in this assay, from the lowest: compounds 3, 2 and 1 (each within the scatter of the next).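

On the sulfonamide nitrogen, hydrogen in place of 3-hydroxypropyl gives a 1.6-fold lower number from compound 1 to compound 3 (0.20 log units; within the scatter) in this assay, so the read-out does not separate the compound that has this chain from the one that lacks it. Going by these compounds alone, this is the first view of this single position, since compound 1 and compound 2 differ too widely to isolate any one group, and it shows that the 3-hydroxypropyl chain, with its hydrogen-bond donor and acceptor, can be removed from the sulfamoyl group with no change beyond the scatter in this assay. Nothing in the data shown bears on why the step is this small.

What the compounds leave open is whether this nitrogen would accept other substituents with the same result, such as a methyl group, a longer chain, or a chain ending in an amine or a carboxylic acid. As far as these compounds go, it also remains unknown whether the sulfamoyl group itself matters at all, a question that replacing it with a carboxamide or a nitrile on the same aniline would address.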